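Swapping an aryl group for an ester on a pyrazole nitrogen

The source may hold more compounds than are shown below. What is called first, only, known or untested is meant among the compounds shown, and "the series" means these compounds.

Compound 1 `Cc1ccccc1-c1nn(-c2ccc(C(F)(F)F)cc2)cc1CNCCN1CCN(C)CC1` and compound 2 `CCCN1CCC(CNCc2cn(-c3ccc([N+](=O)[O-])cc3)nc2-c2ccc(OC(F)(F)F)cc2)CC1` were examined in an ADME assay on Huh-7 cells (Homo sapiens) for cytotoxicity; a lower number here means that less compound is tolerated, a higher number that more compound is tolerated. Compound 1 gives 11000 nM there, the lowest of the two numbers available, while compound 2 gives 18000 nM; the gap between these two values lies within the scatter, so the two compounds cannot be told apart on this assay.

Compound 3 `CCOC(=O)Cn1cc(CNCCN2CCN(C)CC2)c(-c2ccccc2C)n1` is not yet measured in this assay. It differs from compound 1 in one place: (ethoxycarbonyl)methyl in place of 4-(trifluoromethyl)phenyl on an aromatic nitrogen. For the measured compounds named here, no step between two measured compounds has been characterised for a change of this kind, so the two known values give no direct guide to its size.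

The account expects the number for compound 3 in this assay to move upward, though likely not far beyond the scatter, as a step of a 1.8-fold higher number from compound 1 to compound 3 (0.26 log units; within the scatter) from the value of compound 1. Compound 3 is therefore estimated at 20000 nM, with a range from 8000 nM to 50000 nM.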

Compound 3, half-maximal cytotoxic concentration: > 20000 nM
Compound 3: a limit, no number; the forecaster's own chance of this, stated with the estimate: 25%; the middle value lies on the limit itself.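

Compound 3 reads > 20000 nM in this assay, and this value is a limit of the assay, not a number. For the compounds shown here, the step from 4-(trifluoromethyl)phenyl to (ethoxycarbonyl)methyl on the aromatic nitrogen is the first look at this position, and it gives an at least 1.8-fold higher number from compound 1 to compound 3 (0.25 log units; that floor lies within the scatter), so losing the aromatic ring there brings no lower number, though the floor alone does not establish a real rise. The true size of the step stays unfixed, as the reading stops at the assay's ceiling: the limit of > 20000 nM in this assay, at which 1 of the 3 values shown sits.

The compounds shown leave open how far compound 3 lies past its limit. They also do not tell whether a carboxylic acid or a plain ethyl chain in place of the (ethoxycarbonyl)methyl would read the same in this assay.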